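Chloro for Hydrogen: From Compound 3 Toward Compound 4

The source may hold more compounds than are shown below. What is called first, only, known or untested is meant among the compounds shown, and "the series" means these compounds.

Of the compounds shown here, three sharing one core have been tested in an assay on isolated protein for inhibition of Aromatase (Homo sapiens), read by fluorescence and colorimetric assay, with a stated time of 30 min; a lower number here means a stronger inhibitor, a higher number a weaker inhibitor. Compound 1 `Clc1ccc(OCc2cn(C(c3ccccc3)c3ccccc3)nn2)cc1` gives 13400 nM. Compound 2 `N#Cc1ccc(Cn2cc(COc3ccc(Cl)cc3)nn2)cc1` gives 3910 nM. Compound 3 `c1ccc(Cn2cc(COc3ccccc3)nn2)cc1` gives 10600 nM. Among these three numbers compound 3 sits close to compound 1, the two lying within the scatter of each other, while compound 2 stands apart with a lower number that lies beyond the scatter of compound 3.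

Compound 4 `Clc1ccc(OCc2cn(Cc3ccccc3)nn2)cc1` has not yet been measured in this assay. It differs from compound 3 in one place: chloro in place of hydrogen on an aromatic carbon. Among the compounds with values here, no measured pair in the set isolates this same change, so the size of the step can only be judged from what the three numbers show. Compound 1 and compound 2 both carry the chloro group, and only compound 2 reaches a clearly lower number, with a different group elsewhere in its structure.

The step from compound 3 to compound 4 is therefore expected to be small, a 1.5-fold lower number from compound 3 to compound 4 (0.18 log units; within the scatter), pointing toward a somewhat lower number but possibly not beyond the scatter. Compound 4 is estimated to give 7000 nM in this assay, within a range from 2500 nM to 20000 nM.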

Compound 4, half-maximal inhibitory concentration: 5040 nM
Estimate against measurement, compound 4: 1.4-fold (0.14 log units) above; low and high end bracket the measured number.
By their numbers in this assay, from the lowest: compounds 2 and 4 (each within the scatter of the next); then compounds 3 and 1 (each within the scatter of the next).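

In this assay, the change from phenyl to 4-chlorophenyl can now be read directly, and a 2.1-fold lower number from compound 3 to compound 4 (0.32 log units; beyond the scatter) shows that chloro on this aromatic carbon, para to a large group, moves the number modestly but measurably. Compound 4 also separates the two other changes that had been tied up with the chloro group: with hydrogen in place of cyano on an aromatic carbon, a 1.3-fold higher number from compound 2 to compound 4 (0.11 log units; within the scatter) leaves no step beyond the scatter, whereas hydrogen in place of phenyl on the saturated chain carbon gives a 2.7-fold lower number from compound 1 to compound 4 (0.42 log units; beyond the scatter), a modest step of about the same size as the chloro step. Nothing shown gives a measured reason for either step beyond the scatter.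

The compounds shown leave open whether chloro is a particular choice at this place or whether bromo, fluoro, methyl or methoxy in the same place would give a similar step. They also leave open whether the chloro step would be repeated on a compound carrying another group on the saturated chain carbon, such as a second phenyl.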